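The source may report more compounds than this note shows. Statements on the series, on what has been measured and on what is new or still open speak of the compounds shown alone.

Measured so far in a functional assay on HEK293 cells for positive allosteric modulation of metabotropic glutamate receptor 5 (Homo sapiens), read by FLIPR and calcium flux; on this read-out higher numbers stand for an effect only at larger amounts of compound and lower numbers for an effect already at smaller amounts:

Compound 1, `O=C(COCc1ccccc1)N1CCN(c2ccc(F)cc2F)CC1`: 300 nM
Compound 2, `O=C(COCc1ccccc1)N1CCN(c2cc(Cl)ccn2)CC1`: 570 nM
Compound 3, `O=C(COCc1ccncc1)N1CCN(c2ccc(F)cc2F)CC1`: 4600 nM

Compound 3 stands highest of the three in this assay; the step that separates it from the lowest of the three is a 15-fold higher number from compound 1 to compound 3 (1.19 log units; beyond the scatter), and the two cores differ as pyridin-4-yl in place of phenyl on a saturated chain carbon bound to an oxygen on a saturated carbon. The step from compound 1 to compound 2 is a 1.9-fold higher number from compound 1 to compound 2 (0.28 log units; within the scatter); the change behind it is 4-chloropyridin-2-yl in place of 2,4-difluorophenyl on an amine nitrogen in a ring, and on its own it leaves the read-out essentially where it was.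

Compound 4, `O=C(COCc1ccncc1)N1CCN(c2cc(Cl)ccn2)CC1`, has not been measured in this assay. It differs from compound 3 by 4-chloropyridin-2-yl in place of 2,4-difluorophenyl on an amine nitrogen in a ring. The place of this change reads word for word as it does from compound 1 to compound 2, so it is the same change, made here on the core of compound 3 rather than on the core of compound 1. The change appears twice among the compounds considered, once measured and once not.

For compound 4 a step of about a 1.6-fold higher number from compound 3 to compound 4 (0.21 log units; within the scatter) from compound 3 is expected, resting on the measured step of a 1.9-fold higher number from compound 1 to compound 2 (0.28 log units; within the scatter) on the other core, with the caution that the transfer from one core to the other is not itself measured here. On that basis compound 4 is estimated at 7500 nM in this assay, with a likely range from 3000 nM to 20000 nM.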

Compound 4, half-maximal effective concentration: 4200 nM
The estimate for compound 4 lay 1.8-fold (0.25 log units) above the measured number; the measured number falls inside the stated range.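

In this assay, 4-chloropyridin-2-yl in place of 2,4-difluorophenyl on an amine nitrogen in a ring gives a 1.1-fold lower number from compound 3 to compound 4 (0.04 log units; within the scatter) on the core of compound 3, so the exchange leaves the read-out essentially unmoved on both cores, and the two steps agree: the same change on two cores in this assay, a 1.9-fold higher number (0.28 log units; within the scatter) from compound 1 to compound 2 and a 1.1-fold lower number (0.04 log units; within the scatter) from compound 3 to compound 4, 2.1-fold (0.32 log units) apart, within the scatter of two such steps.
Read the other way round, pyridin-4-yl in place of phenyl on a saturated chain carbon bound to an oxygen on a saturated carbon gives a 7.4-fold higher number from compound 2 to compound 4 (0.87 log units; beyond the scatter), again a step beyond the scatter in the same direction as on the core of compound 1, and these two steps also agree: the same change on two cores in this assay, a 15-fold higher number (1.19 log units; beyond the scatter) from compound 1 to compound 3 and a 7.4-fold higher number (0.87 log units; beyond the scatter) from compound 2 to compound 4, 2.1-fold (0.32 log units) apart, within the scatter of two such steps.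
The two changes therefore carried over between the cores of this set of four compounds, but that is one pair of cores in one assay, which shows neither that they would carry over to a third core nor that a small real effect of the first change is absent, since both of its steps lie within the scatter.

The compounds shown leave open whether the higher number seen with pyridin-4-yl extends to pyridin-3-yl or pyridin-2-yl on the same chain carbon. They also leave open how an amine or a longer chain in place of the oxygen-bearing link would read in this assay.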